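The compounds below may be only part of what the source reports. "The series", "measured", "known", "first", "only" and "open" are said of these compounds alone.

Measured so far in a functional assay on MDA-MB-231 cells (Homo sapiens) for antiproliferative activity, read by MTT assay, with a stated time of 24 h; on this read-out higher numbers stand for weaker inhibition and lower numbers for stronger inhibition

- Compound 1 `COC(=O)c1scc(-c2ccc(NC(=O)c3ccc4ccccc4c3)cc2)c1OC` gives 5250 nM
- Compound 2 `COC(=O)c1scc(-c2ccc(NC(=O)c3cccc(C(F)(F)F)c3)cc2)c1OC` gives 24600 nM
- Compound 3 `COC(=O)c1scc(-c2ccc(NC(=O)c3cccc(I)c3)cc2)c1OC` gives 8240 nM

Compound 3 cannot be told apart from compound 1 (a 1.6-fold higher number from compound 1 to compound 3 (0.20 log units; within the scatter)) and lies clearly under compound 2 (a 3.0-fold lower number from compound 2 to compound 3 (0.48 log units; beyond the scatter)). Compound 4 `COC(=O)c1scc(-c2ccc(NC(=O)c3cccc(OC(F)(F)F)c3)cc2)c1OC` changes one place (trifluoromethoxy in place of iodo on an aromatic carbon), with trifluoromethoxy in place of iodo on an aromatic carbon.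

For the measured compounds named here, no measured compound carries trifluoromethoxy, so the data give no direct guide. The nearest group by name is the trifluoromethyl of compound 2, and the swap from that group to iodo gave a 3.0-fold lower number from compound 2 to compound 3 (0.48 log units; beyond the scatter) as its result. Read backwards, that step suggests a rise in the number on going from iodo to trifluoromethoxy. Going by the values given here, the size should be no greater than that step, and it may stay close to the scatter in this assay (an expectation, not a measurement). The estimated change is a 1.9-fold higher number from compound 3 to compound 4 (0.29 log units; within the scatter) as a modest weakening. Compound 4 is expected at about 16000 nM with an estimated range from 7000 nM to 32000 nM as its likely span.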

Compound 4, half-maximal inhibitory concentration: 7540 nM
The estimate for compound 4 lay 2.1-fold (0.33 log units) above the measured number; the range from low to high includes it.
By their numbers in this assay, from the lowest: compounds 1, 4 and 3 (each within the scatter of the next); then compound 2.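

In this assay, placing trifluoromethoxy, with its five heavy atoms and one hydrogen-bond acceptor, where the single iodine atom stood gives a 1.1-fold lower number from compound 3 to compound 4 (0.04 log units; within the scatter), so this aromatic carbon carries two very different groups with no readable difference in the number. Trifluoromethoxy in place of trifluoromethyl gives a 3.3-fold lower number from compound 2 to compound 4 (0.51 log units; beyond the scatter), which shows that two groups that both end in three fluorines and differ by an oxygen can be told apart here, so the fluorines alone do not settle the result. Nothing measured here gives a reason for either step.

Going by these compounds, it remains open whether an amine or a carboxylic acid on this carbon would stay close to compound 4 or fall nearer to compound 2. On these data alone, a plain methoxy group or a single fluorine atom is equally open, and either could show whether the oxygen or the fluorines count for more.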